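The source may report more compounds than this note shows. Statements on the series, on what has been measured and on what is new or still open speak of the compounds shown alone.

For the measured compounds named here, in a functional assay on HeLa cells (Homo sapiens) for inhibition, read by colorimetric assay, with a stated time of 72 h (a higher number here means that more compound is needed for the effect, a lower number that less compound is needed), compound 1 (`COC(=O)Cn1nc2c(n1)C(=O)C(C)=C(C)C2=O`) gives 1 ug/mL and so holds the only true number so far. Compound 2 (`Cc1cc2c(cc1C)[n+]([O-])nn2Cc1ccccc1`) reads > 100 ug/mL as its result, and that is a limit of the assay, not a number. Compound 3 (`CC1=C(C)C(=O)c2nn(C)nc2C1=O`) has not yet been measured. It departs from compound 1 in one place: hydrogen in place of methoxycarbonyl on a saturated chain carbon bound to an aromatic nitrogen. Cut one bond further out, the (methoxycarbonyl)methyl group becomes a methyl, while the core of compound 1 stays as it is. Going by the values given here, no measured pair of compounds isolates this change, so the data do not show directly what it does. The expectation therefore rests on compound 1 at 1 ug/mL as the only anchor, with the core kept intact. The estimated 2.0-fold higher number from compound 1 to compound 3 (0.30 log units; within the scatter) is expected to be small, leaning toward more compound being needed, and it may not rise beyond the usual scatter. For compound 3 the expected value is 2 ug/mL with an estimated range from 0.5 ug/mL to 10 ug/mL once it is measured.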

Compound 3, concentration for half-maximal effect: 0.5 ug/mL
Compound 3: the middle estimate sits 4.0-fold (0.60 log units) above what was measured; the measured number falls inside the stated range.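

In this assay, for the compounds shown here, the first pair that differs in one place gives a 2.0-fold lower number from compound 1 to compound 3 (0.30 log units; within the scatter), with hydrogen in place of methoxycarbonyl on a saturated chain carbon bound to an aromatic nitrogen. Earlier, compound 1 stood alone as an anchor, whereas this step shows that the methoxycarbonyl, with its 4 heavy atoms and 2 hydrogen-bond acceptors, can leave this place with no change beyond the scatter, so the ester is not required for a value of this size on the shared core. The data shown offer no measured property that bears on this step and so give no explanation for it.

From the compounds shown here alone, whether a longer chain, a carboxylic acid or an amine on this saturated chain carbon would keep the value in the same range remains open, since only methoxycarbonyl and hydrogen have been compared here. Going by these compounds alone, compound 2 reads > 100 ug/mL, which is a limit of the assay and not a number, and no step links it to the other compounds, so it cannot be read as a comparison and says nothing about this position.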